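The compounds below may be only part of what the source reports. "The series", "measured", "known", "first", "only" and "open" are said of these compounds alone.

Measured in a functional assay on PC-3 cells (Homo sapiens) for inhibition; a higher number here means a weaker inhibitor, a lower number a stronger inhibitor:

- compound 1 `COc1cc2nc(N3CCN(C(=O)OCc4ccccc4)CC3)nc(N)c2cc1OC`: 63000 nM
- compound 2 `COc1ccc(C(=O)N2CCN(c3nc(N)c4cc(OC)c(OC)cc4n3)CC2)cc1OC`: 71000 nM
- compound 3 `COc1cc2nc(N3CCN(C(=O)c4cccc5ccccc45)CC3)nc(N)c2cc1OC`: 59000 nM

All three share the same core and differ only in the group on the carbonyl carbon of the ring amide. Compound 3 holds the lowest of the three numbers, but the steps to it are small: a 1.1-fold lower number from compound 1 to compound 3 (0.03 log units; within the scatter) and a 1.2-fold lower number from compound 2 to compound 3 (0.08 log units; within the scatter), both within the scatter, so no order among the three can be read. The remaining step, a 1.1-fold higher number from compound 1 to compound 2 (0.05 log units; within the scatter), is likewise within the scatter. Across a benzyloxy, a 3,4-dimethoxyphenyl and a naphthalen-1-yl group on this carbonyl carbon, this assay thus reports the same weak inhibition.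

Compound 4 `COc1cc2nc(N3CCN(C(=O)c4ccc(C(C)(C)C)cc4)CC3)nc(N)c2cc1OC` is the next member. Its change from compound 3: 4-(tert-butyl)phenyl in place of naphthalen-1-yl on a carbonyl carbon. The group that enters carries the same count of heavy atoms as the one that leaves, and the site of the change is the same carbonyl carbon at which the three measured steps were all within the scatter. Those three steps are the only ones that bear on this change, and none of them moved the number. The expected step is therefore a 1.1-fold higher number from compound 3 to compound 4 (0.04 log units; within the scatter), no change beyond the scatter. For compound 4 the estimate in this assay is 65000 nM, within a range of 30000 nM to 140000 nM.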

Compound 4, half-maximal inhibitory concentration: 47000 nM
Beside the measured number, compound 4's estimate is 1.4-fold (0.14 log units) above it; measured number inside the range.
By their numbers in this assay, from the lowest: compounds 4, 3, 1 and 2 (each within the scatter of the next).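

Working notes on the group on the carbonyl carbon: in this assay the new steps are a 1.3-fold lower number from compound 3 to compound 4 (0.10 log units; within the scatter) and a 1.5-fold lower number from compound 2 to compound 4 (0.18 log units; within the scatter) and a 1.3-fold lower number from compound 1 to compound 4 (0.13 log units; within the scatter) and so the 4-(tert-butyl)phenyl group joins the other three groups in a flat set with no order among the four compounds. Among these compounds, what this adds is a change of a different kind at the same position, since a single aromatic ring carrying a tert-butyl group replaces the two aromatic rings of naphthalen-1-yl at an equal heavy-atom count, and still no step leaves the scatter, even for the pairs that also exchange the 3,4-dimethoxyphenyl or benzyloxy groups. No measurement available here accounts for this insensitivity at the carbonyl carbon.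

As far as these compounds go, the four groups are all uncharged and built on carbon rings, so it remains open whether a primary amine or a carboxylic acid on the aromatic ring, or a short alkyl chain in place of the ring on the carbonyl carbon, would move the number in this assay at all. Also open, from the compounds shown here alone, is whether a change to the shared core itself, rather than to this group, would produce a step beyond the scatter.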